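Swapping the sulfonyl aryl group on a serotonin-receptor ligand

This account rests on a few compounds, and the source may have more. Where it says the series, first, only, none or still open, it means among the compounds named here.

Of the compounds shown here, three have so far been tested in an assay on HeLa cells for displacement of a labelled ligand from 5-hydroxytryptamine receptor 6 (Homo sapiens); on this read-out lower numbers stand for stronger inhibition and higher numbers for weaker inhibition. Compound 1 `CCN1CCN(c2cn(S(=O)(=O)c3ccc(C(C)C)cc3)c3ccccc23)CC1` gives 8.6 nM in this assay. Compound 2 `CN1CCN(c2cn(S(=O)(=O)c3ccccc3Br)c3ccc(Br)cc23)CC1` gives 10.2 nM in this assay, and compound 3 `CCN1CCN(c2cn(S(=O)(=O)c3ccc(OC)cc3)c3cc(Cl)ccc23)CC1` gives 82.3 nM in this assay. Among these three numbers compound 2 stands second highest: its nearest neighbour is compound 1, whose number lies within the usual scatter of its own, and its furthest is compound 3, whose number lies beyond that scatter. Going by the values given here, each of the three differs from the others in more than one place, so no single structural step among them has been isolated.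

Compound 4 `CN1CCN(c2cn(S(=O)(=O)c3ccc(F)cc3)c3ccc(Br)cc23)CC1` has not yet been measured. It differs from compound 2 in one place: 4-fluorophenyl in place of 2-bromophenyl on a sulfonyl sulfur. Among the compounds with values here, no pair of measured compounds isolates a change of this kind, so there is no measured step to lean on, and the expectation rests on compound 2 alone. The expected step is a 1.2-fold higher number from compound 2 to compound 4 (0.07 log units; within the scatter), which need not reach beyond the scatter in either direction. In this assay compound 4 is therefore expected to give roughly 12 nM, with a likely range from 4 nM to 40 nM.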

Compound 4, inhibition constant: 9.2 nM
Estimate against measurement, compound 4: 1.3-fold (0.12 log units) above; the measured number falls inside the stated range.
By their numbers in this assay, from the lowest: compounds 1, 4 and 2 (each within the scatter of the next); then compound 3.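

In this assay, going by these compounds alone, putting 4-fluorophenyl in place of 2-bromophenyl on a sulfonyl sulfur gives a 1.1-fold lower number from compound 2 to compound 4 (0.04 log units; within the scatter), the first comparison in this set in which only one place differs. At this position, with the rest of compound 2 left as it is, these two aryl groups therefore cannot be told apart on this read-out, even though they carry different halogens at different places on the ring. Nothing measured here explains why the two groups read alike.

Going by these compounds, both groups are halogen-bearing phenyl rings, so it remains open whether a pyridine ring, a plain phenyl ring or a phenyl ring carrying a carboxylic acid or an amine would read the same on this sulfonyl sulfur. On these data alone, it is also open whether the same swap would read alike on a core without the bromine that compound 2 and compound 4 share.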